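A few compounds are considered here, and "the series" means these few. Any claim that something is new, unique, unknown or untested is made for them only; others in the source may bear on it.

Compound 1 `CC(C)Nc1nccc(-c2cn[nH]c2)n1` gives 0.021 mL/min/kg in an in vitro ADME assay on microsomes from liver (Homo sapiens) for metabolic stability; a lower number here means slower removal, a higher number faster removal of the compound.
Compound 2 `CC(C)Nc1nccc(-c2c[nH]nc2-c2ccc(Cl)cc2)n1` gives 0.106 mL/min/kg in this assay.
Compound 3 `CC(C)Nc1nccc(-c2c[nH]nc2C2CCCCO2)n1` gives 0.021 mL/min/kg in this assay.

Among these three measured compounds, compound 2 shows the highest number in this assay, meaning it is removed fastest. Its distance from the others is the same in each direction: going a 5.0-fold higher number from compound 1 to compound 2 (0.70 log units; beyond the scatter) and going a 5.0-fold lower number from compound 2 to compound 3 (0.70 log units; beyond the scatter). The two compounds with the lower number, compound 1 and compound 3, give values within the scatter of each other, as seen in no change at the digits printed from compound 1 to compound 3 (within the scatter).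

Compound 4 `Clc1ccc(-c2n[nH]cc2-c2ccnc(NC3CCCCC3)n2)cc1` is the next compound to be measured. It differs from compound 2 in a single place: cyclohexyl in place of isopropyl on a nitrogen on an aromatic ring. For the measured compounds named here, none of the measured steps touches this part of the molecule; every one of them changes what sits on an aromatic carbon on the other side of the shared core, while the isopropylamino group stays fixed in compounds 1, 2 and 3. Going by the values given here, there is therefore no measured step that bears directly on this change, and the expectation must rest on compound 2 itself. The step from compound 2 to compound 4 is expected to be small, a 1.3-fold higher number from compound 2 to compound 4 (0.12 log units; within the scatter), most likely within the scatter. Compound 4 is therefore estimated at 0.14 mL/min/kg, within a range from 0.06 mL/min/kg to 0.35 mL/min/kg.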

Compound 4, clearance: 0.156 mL/min/kg
Compound 4: middle estimate off by 1.1-fold (0.05 log units), on the low side; the range from low to high includes it.
By their numbers in this assay, from the lowest: compounds 1 and 3 (each within the scatter of the next); then compounds 2 and 4 (each within the scatter of the next).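

For the compounds shown here, until this point, every measured step changed a group on an aromatic carbon while the isopropylamino group stayed fixed, so this is the first information about the group on the nitrogen. In this assay, replacing isopropyl with cyclohexyl gives a 1.5-fold higher number from compound 2 to compound 4 (0.17 log units; within the scatter) and so stays inside the usual scatter, even though the group grows from 3 to 6 heavy atoms and gains a six-membered non-aromatic ring of carbon only, whereas the change on the aromatic carbon that introduced 4-chlorophenyl gave a 5.0-fold higher number from compound 1 to compound 2 (0.70 log units; beyond the scatter) and lay beyond it. No measurement shown here offers an explanation for this result.

Going by these compounds, this single pair carries 4-chlorophenyl throughout, so it remains open whether cyclohexyl would behave the same way on the lower-numbered compound 1 or compound 3. Also open, on these data alone, is how this nitrogen would respond to a different kind of group, such as a piperidine, a longer alkyl chain or a cyclohexyl ring carrying a hydroxyl group.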